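Fused pyridine series: aryl substituent at the saturated ring carbon

This account rests on a few compounds, and the source may have more. Where it says the series, first, only, none or still open, it means among the compounds named here.

Measured so far:
compound 1 `N#CC1=C(N)N(c2ccc(S(N)(=O)=O)cc2)C2=C(C(=O)CCC2)C1/C=C/c1ccccc1` — 40%
compound 2 `COc1cc(CC2C(C#N)=C(N)N(c3ccc(S(N)(=O)=O)cc3)C3=C2C(=O)CCC3)ccc1O` — 90%

In a functional assay on Ehrlich cells (Mus musculus) for antiproliferative activity, read by trypan blue exclusion, with a stated time of 2 h, tested at 50 ug/mL (on this read-out higher numbers stand for a stronger effect at the one concentration tested and lower numbers for a weaker effect), compound 2 gives 90%, the higher of the two numbers; its nearest neighbour is compound 1 at 40%. Going by the values given here, the one step measured between compounds that differ in a single place is a number 50 percentage points higher from compound 1 to compound 2 (beyond the scatter), a large shift.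

Compound 3 `N#CC1=C(N)N(c2ccc(S(N)(=O)=O)cc2)C2=C(C(=O)CCC2)C1c1cccc([N+](=O)[O-])c1` is not yet measured. It differs from compound 2 by 3-nitrophenyl in place of 4-hydroxy-3-methoxybenzyl on a saturated ring carbon. Among the compounds with values here, the only step that bears on this change is the one from compound 1 to compound 2, which shows that exchanging the group on this saturated ring carbon can move this assay a long way. Within the data shown here, no measured pair covers the 3-nitrophenyl group, so direction and size for compound 3 are uncertain; the group also sits on the ring carbon without the one-carbon link present in compound 2. The expectation is therefore a step of a number 35 percentage points lower from compound 2 to compound 3 (beyond the scatter), downward from compound 2. Compound 3 is estimated at 55%, with a range from 25% to 85%.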

Compound 3, a percentage reported as activity, at one concentration (the size of the read-out at that concentration, not a potency): 73%
Estimate against measurement, compound 3: 18 percentage points below, within the range that was stated.
By their numbers in this assay, from the lowest: compound 1; then compound 3; then compound 2.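

In this assay the step from 2-phenylethenyl to 3-nitrophenyl on the saturated ring carbon is a number 33 percentage points higher from compound 1 to compound 3 (beyond the scatter), so among these three compounds the gain over 2-phenylethenyl is not confined to 4-hydroxy-3-methoxybenzyl. This gain arises with an aryl group that sits on the ring carbon without the one-carbon link and carries a nitro group instead of the hydroxy and methoxy groups. Going by these compounds alone, exchanging 4-hydroxy-3-methoxybenzyl for 3-nitrophenyl gives a number 17 percentage points lower from compound 2 to compound 3 (beyond the scatter), a smaller move than the one separating compound 1 from compound 3, and no measurement on these compounds gives a reason for this order of the three groups.

Going by these compounds, the link and the ring substituents change together between compound 2 and compound 3, so the share of each in this step stays open; 4-hydroxy-3-methoxyphenyl attached directly to the ring carbon and 3-nitrobenzyl would separate them. Also open, on these data alone, is how this position responds to a group without an aromatic ring, such as a saturated alkyl chain, or to an aryl group carrying an amine or a carboxylic acid.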